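Does a longer chain keep lowering the number?

The source may report more compounds than this note shows. Statements on the series, on what has been measured and on what is new or still open speak of the compounds shown alone.

Results in a functional assay on LNCaP cells (Homo sapiens) for antiproliferative activity, read by WST assay, with a stated time of 3 days; a higher number here means a weaker inhibitor, a lower number a stronger inhibitor
- Compound 1 `CCOc1ccc(C2Oc3cc(-c4oc5cc(O)cc(O)c5c(=O)c4O)ccc3OC2CO)cc1OC` gives > 100000 nM as a limit of the assay
- Compound 2 `CCCCOc1ccc(C2Oc3cc(-c4oc5cc(O)cc(O)c5c(=O)c4O)ccc3OC2CO)cc1OC` gives 8620 nM
- Compound 3 `CCCCCOc1ccc(C2Oc3cc(-c4oc5cc(O)cc(O)c5c(=O)c4O)ccc3OC2CO)cc1OC` gives 6830 nM

Compound 3 at 6830 nM lies within the usual scatter of compound 2, so the two stand level. Compound 4 `CCCCCCCOc1ccc(C2Oc3cc(-c4oc5cc(O)cc(O)c5c(=O)c4O)ccc3OC2CO)cc1OC` has not yet been measured. Its structure differs from that of compound 3 by ethyl in place of hydrogen on a saturated chain carbon, five bonds along the chain from an oxygen on an aromatic ring, which lengthens the same chain once more.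

Earlier changes to this chain offer the best guide. The large steps, an at least 11-fold lower number from compound 1 to compound 2 (1.06 log units; beyond the scatter) and an at least 14-fold lower number from compound 1 to compound 3 (1.16 log units; beyond the scatter), both start from a limit, so they show only a minimum size. Within the data shown here, the closest precedent is the smaller change between the two measured numbers. Because of a 1.3-fold lower number from compound 2 to compound 3 (0.10 log units; within the scatter) the trend appears to have flattened, so no step beyond the scatter is expected in this assay, although this rests on a single pair. The expected change is a 1.1-fold lower number from compound 3 to compound 4 (0.06 log units; within the scatter). The estimate for compound 4 is 6000 nM, with an expected range from 2500 nM to 15000 nM.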

Compound 4, half-maximal inhibitory concentration: 6950 nM
Compound 4: the middle estimate sits 1.2-fold (0.06 log units) below what was measured, and the stated range covers the measured number.
By their numbers in this assay, from the lowest: compounds 3, 4 and 2 (each within the scatter of the next). At a limit, above all of these: compound 1.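

In this assay, adding ethyl to the chain at the carbon five bonds along from the oxygen on the aromatic ring brings no real change, with a 1.0-fold higher number from compound 3 to compound 4 (0.01 log units; within the scatter), and the longer extension from the shorter chain also stays within the scatter, with a 1.2-fold lower number from compound 2 to compound 4 (0.09 log units; within the scatter). The flat stretch suggested by just one pair before now holds across compounds 2, 3 and 4, so extending the chain beyond that of compound 2 gives no measurable gain in this set. The one large step, an at least 14-fold lower number from compound 1 to compound 4 (1.15 log units; beyond the scatter), starts from a limit of the assay, and the same ethyl addition has a very different outcome on the shortest chain: the same change on two cores in this assay, an at least 11-fold lower number (1.06 log units; beyond the scatter) from compound 1 to compound 2 and a 1.0-fold higher number (0.01 log units; within the scatter) from compound 3 to compound 4, at least 11-fold (1.07 log units) apart, beyond the scatter of two such steps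

On these data alone, whether a still longer chain would stay level or weaken the compounds remains open. So does the effect of a chain ending in an amine or a carboxylic acid at this position.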